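Propyl Swapped for Isopropyl on a Shared Core

A few compounds are considered here, and "the series" means these few. Any claim that something is new, unique, unknown or untested is made for them only; others in the source may bear on it.

The compounds measured so far, each in a functional assay for inhibition, with Homo sapiens as the target; on this read-out higher numbers stand for weaker inhibition and lower numbers for stronger inhibition:

Compound 1 `Cc1nc(C)n2c(=O)n(C)ncc12`: > 48000 nM, a limit of the assay rather than a number.
Compound 2 `CCCc1ncn2c(Nc3cc[nH]n3)nccc12`: > 48000 nM, again a limit of the assay rather than a number.
Compound 3 `C=CCSc1nncc2cnc(C)n12`: 61000 nM.

Compound 2 therefore stands not at a measured number but at the limit of > 48000 nM in this assay, at which 2 of the 3 values shown sit. Among the measured compounds shown here, the value of compound 3 is a true number, yet it lies in the same weak region, so nothing among the three compounds separates one from another by more than the usual scatter, and no step between two measured compounds that differ in a single place exists here.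

Compound 4 `CC(C)c1ncn2c(Nc3cc[nH]n3)nccc12` is the next compound to be measured in this assay. It is built from the same atoms as compound 2, joined differently: isopropyl in place of propyl on an aromatic carbon. Both groups carry no ring, no hydrogen-bond donor or acceptor, and no charge.

For the measured compounds named here, with no measured step to lean on, the expectation for compound 4 rests on compound 2 alone, whose result was only a limit. The change from propyl to isopropyl is expected to give no step beyond the scatter, that is a step that the limit leaves unreadable from compound 2 to compound 4. Compound 4 is thus estimated to give about 60000 nM, in a range from 20000 nM to 200000 nM, most likely reported again only as a limit.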

Compound 4, half-maximal inhibitory concentration: > 48000 nM
Compound 4 gave a limit, no number; the forecaster's own chance of this, stated with the estimate: 80%; the middle value does not contradict the limit.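

No step from compound 2 to compound 4 can be read, because both results are limits of the assay and not numbers: the limit of > 48000 nM in this assay, at which 3 of the 4 values shown sit.

On these data alone, whether propyl and isopropyl in this place differ at all on the shared core stays open, and so does how strongly either compound inhibits.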